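Replacing the tetrazole of compound 3: notes and an estimate

A few compounds are considered here, and "the series" means these few. Any claim that something is new, unique, unknown or untested is made for them only; others in the source may bear on it.

The series is followed in an assay on cells for binding affinity to Myc proto-oncogene protein (Homo sapiens); on this read-out lower numbers stand for stronger inhibition and higher numbers for weaker inhibition. Compound 1 `N#Cc1ccc(-c2cc(-c3ccc(C(N)=O)cc3)cc(-c3cncs3)n2)cc1` gives 30000 nM. Compound 2 `NC(=O)c1ccc(-c2cc(-c3ccc(-c4cnco4)cc3)nc(-c3ccco3)c2)cc1` gives 2500 nM. Compound 3 `N#Cc1ccc(-c2cc(-c3ccc(-c4nnn[nH]4)cc3)cc(-c3ccco3)n2)cc1` gives 2000 nM, the lowest of the three numbers: the gap to compound 2 lies within the scatter, so no order between these two is claimed, while the gap to compound 1 lies beyond it. For the measured compounds named here, compound 1 and compound 2 each differ from compound 3 in more than one place, so no pair of measured compounds supplies a single-change step that could be used for calibration.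

Compound 4 `N#Cc1ccc(-c2cc(-c3ccc(C(=O)NN)cc3)cc(-c3ccco3)n2)cc1` is the next compound and differs from compound 3 in one place only: aminocarbamoyl in place of 1H-tetrazol-5-yl on an aromatic carbon. Compound 1 carries a carboxamide on the corresponding ring, but it also differs from compound 3 in its five-membered heteroaromatic ring, so its high number cannot be attributed to the amide alone. Going by the values given here, with no directly comparable step available, a moderate move toward a higher number is expected, probably just beyond the scatter, and the expected step is a 3.0-fold higher number from compound 3 to compound 4 (0.48 log units; beyond the scatter). Compound 4 is thus expected to give 6000 nM, with a range from 2000 nM to 20000 nM.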

Compound 4, half-maximal inhibitory concentration: > 100000 nM
Compound 4 ended at the assay's limit; the forecaster's own chance of this, stated with the estimate: 10%; middle value at least 16-fold (1.22 log units) from the limit.
By their numbers in this assay, from the lowest: compounds 3 and 2 (each within the scatter of the next); then compound 1. At a limit, above all of these: compound 4.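

In this assay, for the compounds shown here, this is the first single-change step, and it shows that the aromatic carbon para to a large group is sensitive to what it carries: an at least 50-fold higher number from compound 3 to compound 4 (1.69 log units; beyond the scatter). Compound 4 stands at a limit of the assay rather than at a number: the limit of > 100000 nM in this assay, at which 1 of the 4 values shown sits. Aminocarbamoyl therefore does not serve as a replacement for 1H-tetrazol-5-yl on the core of compound 3, although this single step cannot separate the loss of the five-membered aromatic ring from the other differences between the two groups, and no measured property ties the step to any one of them.

The compounds shown leave open whether an aromatic ring at this carbon is what matters, or whether an open-chain group could also hold the number of compound 3. A carboxylic acid, a plain carboxamide or an aminomethyl group in the same place on the same core would help to separate these readings, as would a different five-membered aromatic ring such as an oxadiazole.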